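A few compounds are considered here, and "the series" means these few. Any claim that something is new, unique, unknown or untested is made for them only; others in the source may bear on it.

Series notes. Compound 1 `Cc1cc(C)c2cc(C#N)c(NCCNC(=O)c3cccnc3)nc2c1` gives in an in vitro assay on FRT cells with Cystic fibrosis transmembrane conductance regulator variant F508del (Homo sapiens) as the target, read by fluorescence, with a stated time of 24 h, at 37 degrees C, in the presence of a further agent that is not named here (on this read-out higher numbers stand for an effect only at larger amounts of compound and lower numbers for an effect already at smaller amounts), a value of 2700 nM. Compound 2 `COc1ccc(C(=O)NCCNc2nc3cc(C)cc(C)c3cc2C#N)c(OC)c1` gives in this assay a value of 4200 nM. Going by the values given here, only these two compounds have been measured, and compound 2 is separated from compound 1 by a 1.6-fold higher number from compound 1 to compound 2 (0.19 log units; within the scatter), a gap that does not set the two apart; the sole change there was 2,4-dimethoxyphenyl in place of pyridin-3-yl on a carbonyl carbon.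

Compound 3 `COc1ccc(C(=O)NCCNc2nc3cc(C)cc(C)c3cc2C#N)cc1OC` has not yet been measured in this assay. It differs from compound 2 by 3,4-dimethoxyphenyl in place of 2,4-dimethoxyphenyl on a carbonyl carbon. Among the compounds with values here, the one measured step that bears on this place is a 1.6-fold higher number from compound 1 to compound 2 (0.19 log units; within the scatter), which exchanged the whole aryl group on that carbonyl carbon without moving the number beyond the scatter. Rearranging the two methoxy groups on an otherwise unchanged ring is a smaller alteration than that full exchange, so no step beyond the scatter is expected in this assay. The expected step is a 1.1-fold lower number from compound 2 to compound 3 (0.02 log units; within the scatter). Compound 3 is therefore expected to give 4000 nM in this assay, within a range from 1500 nM to 11000 nM.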

Compound 3, half-maximal effective concentration: 1500 nM
Compound 3: middle estimate off by 2.7-fold (0.43 log units), on the high side; the measured number falls inside the stated range.
By their numbers in this assay, from the lowest: compounds 3, 1 and 2 (each within the scatter of the next, the first and the last beyond it).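

Going by these compounds alone, exchanging 2,4-dimethoxyphenyl for 3,4-dimethoxyphenyl on a carbonyl carbon whose other neighbour is an amide-type nitrogen gives a 2.8-fold lower number from compound 2 to compound 3 (0.45 log units; beyond the scatter) in this assay, the only step in this set that lies beyond the scatter, so the number at this position depends on how the two methoxy groups are arranged and not only on which aryl group is present. The exchange of pyridin-3-yl for 3,4-dimethoxyphenyl gives a 1.8-fold lower number from compound 1 to compound 3 (0.26 log units; within the scatter), so that aryl exchange does not set its two compounds apart, and the measured separation remains confined to the two dimethoxyphenyl arrangements. Nothing available explains the difference between these two arrangements.

As far as these compounds go, whether the step follows from losing the 2-methoxy group, gaining the 3-methoxy group or only from the pair taken together remains open, and phenyl, 3-methoxyphenyl and 4-methoxyphenyl on the same carbonyl carbon would separate these readings. From the compounds shown here alone, it also remains open whether the same arrangement gives a step of similar size with a longer chain in place of the ethylene chain joining the two nitrogens.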